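Fluorine pattern on the phenoxy ring of a urea series

The source may hold more compounds than are shown below. What is called first, only, known or untested is meant among the compounds shown, and "the series" means these compounds.

Measured so far:
compound 1 `Cn1nc(COc2ccc(F)c(F)c2)c2c1CCN(C(=O)Nc1ccc(Cl)cc1)C2`, 4600 nM
compound 2 `Cn1nc(COc2cc(F)c(F)c(F)c2)c2c1CCN(C(=O)Nc1ccc(Cl)cc1)C2`, 3300 nM

Both values come from an assay on cells for inhibition of Pendrin (Mus musculus), read by fluorescence, with a stated time of 10 min; a higher number here means a weaker inhibitor, a lower number a stronger inhibitor. Compound 2 holds the lowest of the two numbers; its nearest neighbour is compound 1, and the step of a 1.4-fold lower number from compound 1 to compound 2 (0.14 log units; within the scatter) is within the scatter, so the two compounds stand level. Compound 3 `Cn1nc(COc2cc(F)cc(F)c2)c2c1CCN(C(=O)Nc1ccc(Cl)cc1)C2` is not yet measured. It differs from compound 2 by hydrogen in place of fluoro on an aromatic carbon, which turns 3,4,5-trifluorophenoxy into 3,5-difluorophenoxy. Among the compounds with values here, the only step that bears on it is the reverse of the change from compound 1 to compound 2, where a fluoro entered on the same ring, and a 1.4-fold lower number from compound 1 to compound 2 (0.14 log units; within the scatter) stayed within the scatter. Removing one fluoro from compound 2 is therefore expected to give no step beyond the scatter in this assay, that is a 1.2-fold higher number from compound 2 to compound 3 (0.08 log units; within the scatter). Compound 3 is estimated at 4000 nM, with a range of 2000 nM to 8000 nM.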

Compound 3, half-maximal inhibitory concentration: 3100 nM
Beside the measured number, compound 3's estimate is 1.3-fold (0.11 log units) above it; measured number inside the range.
By their numbers in this assay, from the lowest: compounds 3, 2 and 1 (each within the scatter of the next).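

In this assay the fluoro on the aromatic carbon ortho to two fluoro groups and para to a large group can give way to hydrogen with no step beyond the scatter: 3,4,5-trifluorophenoxy to 3,5-difluorophenoxy is a 1.1-fold lower number from compound 2 to compound 3 (0.03 log units; within the scatter). The second new comparison, 3,4-difluorophenyl to 3,5-difluorophenyl, is a 1.5-fold lower number from compound 1 to compound 3 (0.17 log units; within the scatter), so compounds 1, 2 and 3 stand level and these three fluorine patterns are not told apart by this read-out. No other data bear on this result.

As far as these compounds go, what a different group at this position, such as methoxy, an amine or a carboxylic acid, would give remains open. Also open, from the compounds shown here alone, is the result for a phenoxy ring carrying no fluoro at all, or for an amide in place of the urea.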